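This account rests on a few compounds, and the source may have more. Where it says the series, first, only, none or still open, it means among the compounds named here.

Working notes on the series

The shared core carries a vinyl methyl sulfoxide side chain, and the three measured compounds differ only in the substituent on the aromatic ring. In a functional assay on DLD-1 cells (Homo sapiens) for cytotoxicity, with a stated time of 48 h (a higher number here means a weaker inhibitor, a lower number a stronger inhibitor), compound 1 `COc1cccc2c(=O)cc(/C=C/[S+](C)[O-])oc12` gives 9000 nM, compound 2 `CC(C)COc1ccc2oc(/C=C/[S+](C)[O-])cc(=O)c2c1` gives 5000 nM, and compound 3 `Cc1cccc2oc(/C=C/[S+](C)[O-])cc(=O)c12` gives 5500 nM. Compound 2 sits at the lowest of the three numbers, but its gap to compound 3 and its gap to compound 1 both fall within the usual scatter of repeated measurements, so no ranking among the three is claimed.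

Compound 4 `CC(C)CC(=O)Oc1ccc2oc(/C=C/[S+](C)[O-])cc(=O)c2c1` has not been measured. It differs from compound 2 in one place: isobutylcarbonyl in place of isobutyl on an oxygen on an aromatic ring. Nothing in the measured set isolates the effect of the isobutylcarbonyl in place of isobutyl on an oxygen on an aromatic ring, since all three measured compounds keep an ether or alkyl substituent there.

Because compound 2 gives 5000 nM in this assay and the other two measured compounds stay within the scatter of that number, no step beyond the scatter is expected from compound 2 to compound 4, and the expected step is a 1.2-fold higher number from compound 2 to compound 4 (0.08 log units; within the scatter). Compound 4 is estimated at 6000 nM, with a range from 2500 nM to 15000 nM.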

Compound 4, half-maximal inhibitory concentration: 6100 nM
Compound 4: the middle estimate sits 1.0-fold (0.01 log units) below what was measured; the measured number falls inside the stated range.
By their numbers in this assay, from the lowest: compounds 2, 3, 4 and 1 (each within the scatter of the next).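

Going by these compounds alone, the pair compound 2 and compound 4 is the first to differ in one place, and it gives a direct reading at this oxygen on an aromatic ring: isobutylcarbonyl in place of isobutyl gives a 1.2-fold higher number from compound 2 to compound 4 (0.09 log units; within the scatter) in this assay. The entering group brings a carbonyl and one hydrogen-bond acceptor, yet this read-out does not separate isobutoxy from (isobutylcarbonyl)oxy. Nothing shown here offers an explanation for this result.

From the compounds shown here alone, whether other groups on this oxygen would also stay within the scatter remains open, for instance a free hydroxyl, an aminoethyl chain or a longer acyl chain such as octanoyl. Going by these compounds, it is also open whether a carboxylic acid at the end of the isobutylcarbonyl chain would shift the number beyond the scatter.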